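Replacing a Sulfonamide Arm With a Small Alkenyl Amine

The compounds below may be only part of what the source reports. "The series", "measured", "known", "first", "only" and "open" are said of these compounds alone.

Measured compounds:
- compound 1, `O=S(=O)(NCC1CCN(CCCc2c[nH]c3ccc(-n4cnnc4)cc23)CC1)c1ccccc1`: 6.2 nM
- compound 2, `CN(Cc1cccs1)C1CCN(CCCc2c[nH]c3ccc(-n4cnnc4)cc23)CC1`: 4.3 nM
- compound 3, `C[C@@H](NC1CCN(CCCc2c[nH]c3ccc(-n4cnnc4)cc23)CC1)c1ccccc1`: 0.4 nM

In an assay on CHO cells for displacement of a labelled ligand from 5-hydroxytryptamine receptor 1D (Homo sapiens) (a lower number here means a stronger inhibitor, a higher number a weaker inhibitor), compound 1 gives the highest of the three numbers. Compound 2 is its nearest neighbour, and the change a 1.4-fold lower number from compound 1 to compound 2 (0.16 log units; within the scatter) stays within the scatter. Compound 3 is the furthest, with a 16-fold lower number from compound 1 to compound 3 (1.19 log units; beyond the scatter), a large move to a stronger inhibitor.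

Compound 4, `CC(C)=CCN(C)C1CCN(CCCc2c[nH]c3ccc(-n4cnnc4)cc23)CC1`, is not yet measured. It differs from compound 1 by methyl(3-methylbut-2-en-1-yl)amino in place of ((phenylsulfonyl)amino)methyl on a saturated ring carbon. The step from compound 1 to compound 2 bears most on this, since there too a sulfonamide-bearing arm gave way to an amino group carrying a methyl and one further group, and that step stayed within the scatter. The step to compound 3, where the amino group carries a single 1-phenylethyl group, was large, but that pattern rests on one compound only. The expectation for compound 4 is therefore a step within the scatter, a 1.2-fold lower number from compound 1 to compound 4 (0.09 log units; within the scatter). Compound 4 is estimated at 5 nM, in the range 1.5 nM to 15 nM.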

Compound 4, half-maximal inhibitory concentration: 0.5 nM
The estimate for compound 4 lay 10-fold (1.00 log units) above the measured number; the whole stated range lies above it.
By their numbers in this assay, from the lowest: compounds 3 and 4 (each within the scatter of the next); then compounds 2 and 1 (each within the scatter of the next).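

In this assay, the change gives a 12-fold lower number from compound 1 to compound 4 (1.09 log units; beyond the scatter), so at this saturated ring carbon an amino arm with no ring at all can replace the sulfonamide arm with a large shift to a stronger inhibitor. Within the methylated amine, 2-methylprop-1-en-1-yl in place of thiophen-2-yl gives an 8.6-fold lower number from compound 2 to compound 4 (0.93 log units; beyond the scatter), and the further comparison gives a 1.3-fold higher number from compound 3 to compound 4 (0.10 log units; within the scatter), so among these compounds neither an aromatic ring in the arm nor a hydrogen on the amine nitrogen is needed for a low number, while compound 2 shows that a methylated amine alone does not ensure one. Nothing available explains these differences.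

On these data alone, it remains open whether the double bond matters, which a saturated 3-methylbutyl group would test. A plain dimethylamino group would show how much of the arm is needed at all.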